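Hydroxy added to the methoxyphenyl ring of compound 3

The source may hold more compounds than are shown below. What is called first, only, known or untested is meant among the compounds shown, and "the series" means these compounds.

In a functional assay on KB cells (Homo sapiens) for antiproliferative activity, read by MTT assay, with a stated time of 72 h (on this read-out lower numbers stand for stronger inhibition and higher numbers for weaker inhibition), compound 1 `COc1ccc(-c2ssc(=O)c2-c2cc(OC)c(OC)c(OC)c2)cc1` gives 324 nM, compound 2 `COc1ccc(-c2ssc(=O)c2-c2cc(OC)c(OC)c(OC)c2)cc1[N+](=O)[O-]` gives 22300 nM and compound 3 `COc1ccc(-c2ss/c(=N/O)c2-c2cc(OC)c(OC)c(OC)c2)cc1` gives 13700 nM. Compound 3 thus lies within the scatter of compound 2, and its number stands well above that of compound 1. The change to compound 4 `COc1ccc(-c2ss/c(=N/O)c2-c2cc(OC)c(OC)c(OC)c2)cc1O` is hydroxy in place of hydrogen on an aromatic carbon, turning 4-methoxyphenyl into 3-hydroxy-4-methoxyphenyl. For the measured compounds named here, the only measured step that bears on this is a 69-fold higher number from compound 1 to compound 2 (1.84 log units; beyond the scatter), large and upward, with nitro in place of hydrogen on an aromatic carbon. Going by the values given here, that step involves a different group and a different core, and no measured step involves hydroxy, so it is a weak guide. The expected step is a 1.4-fold lower number from compound 3 to compound 4 (0.14 log units; within the scatter), which would be none beyond the scatter. For compound 4 the estimate is 10000 nM, with an expected range of 2000 nM to 40000 nM.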

Compound 4, half-maximal inhibitory concentration: 850 nM
Compound 4: middle estimate off by 12-fold (1.07 log units), on the high side; measured number outside the range, below it.
By their numbers in this assay, from the lowest: compound 1; then compound 4; then compounds 3 and 2 (each within the scatter of the next).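

In this assay, hydroxy in place of hydrogen on an aromatic carbon, ortho to a methoxy group, gives a 16-fold lower number from compound 3 to compound 4 (1.21 log units; beyond the scatter) and so marks this change as a large gain on the oxime core of compound 3. The earlier step on this ring ran the other way, with nitro on the core of compound 1 giving a 69-fold higher number from compound 1 to compound 2 (1.84 log units; beyond the scatter), but group and core both differ, so the two steps cannot separate their contributions. No measurement available here explains the hydroxy step.

Open, from the compounds shown here alone, is whether an amine in place of this hydroxy keeps the gain. Also open, going by these compounds, is whether hydroxy on the core of compound 1 acts as it does on compound 3.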